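The source may hold more compounds than are shown below. What is called first, only, known or untested is meant among the compounds shown, and "the series" means these compounds.

Measured compounds in the series:

Compound 1, `Cn1c(COc2cccc(C(=O)O)c2)nc2cnc(Oc3ccc(Cl)c(F)c3)cc21` — 11 ug/mL
Compound 2, `Cn1c(COc2cccc(C(=O)O)c2)nc2ccc(Oc3cccc(Cl)n3)cc21` — 7.7 ug/mL

In a physicochemical assay for solubility, read by HPLC, measured as thermodynamic solubility, with a stated time of 4 h, at pH 6.8 (on this read-out higher numbers stand for higher solubility and lower numbers for lower solubility), compound 1 gives 11 ug/mL. In this assay, among the measured compounds shown here, compound 2 gives 7.7 ug/mL, the lowest of the two numbers so far, though its nearest neighbour, compound 1, sits within the scatter of it, so the two compounds cannot be placed in any order on this read-out.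

Compound 3, `Cc1ccc(Oc2ccc3nc(COc4cccc(C(=O)O)c4)n(C)c3c2)nc1C`, has not yet been measured in this assay. It differs from compound 2 in one place:

5,6-dimethylpyridin-2-yl in place of 6-chloropyridin-2-yl on an oxygen on an aromatic ring

For the measured compounds named here, no step between two measured compounds carries the same change, so nothing measured here tells the direction or size of its effect. Both groups that leave and enter carry the same count of donors and acceptors and no net charge, and only the substituents on the six-membered aromatic ring change. The step from compound 2 to compound 3 is therefore expected to stay within the usual scatter, with no direction claimed beyond it, which gives a 1.2-fold lower number from compound 2 to compound 3 (0.07 log units; within the scatter). On that basis compound 3 is estimated at 6.5 ug/mL in this assay, with a range from 2.5 ug/mL to 17 ug/mL.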

Compound 3, solubility: 190 ug/mL
Compound 3: the middle estimate sits 29-fold (1.47 log units) below what was measured, and the stated range ends below it.
By their numbers in this assay, from the lowest: compounds 2 and 1 (each within the scatter of the next); then compound 3.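

In this assay, the group on the oxygen on an aromatic ring proves to be a position where a single change can move the read-out strongly: 5,6-dimethylpyridin-2-yl in place of 6-chloropyridin-2-yl gives a 25-fold higher number from compound 2 to compound 3 (1.39 log units; beyond the scatter). This large step comes with the same six-membered aromatic ring, the same count of donors and acceptors and no net charge on either side, so those counted features alone do not mark the change as a small one, something compound 1 and compound 2 could not show as they differ in more than one place. Nothing measured in the series speaks to what lies behind the step.

The change removes a chlorine and brings in two methyl groups at once, so the compounds shown do not separate the contribution of each, and a pyridin-2-yl bearing a single methyl, or none at all, would be the direct comparison. Also open, going by these compounds, is whether the same exchange on the core of compound 1 gives a step of similar size, and how an amine or a methoxy on this ring would read.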